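Triazole Aryl Variation in a Cytotoxicity Series

This account rests on a few compounds, and the source may have more. Where it says the series, first, only, none or still open, it means among the compounds named here.

Measured compounds:
Compound 1, `C=C1C[C@]23C[C@@]1(O)CC[C@H]2c1ccc(O)c(C)c1[C@@H]3Cn1cc(-c2ccccn2)nn1`: in a functional assay on A549 cells (Homo sapiens) for cytotoxicity, read by MTT assay, with a stated time of 4 days (on this read-out lower numbers stand for stronger inhibition and higher numbers for weaker inhibition), compound 1 gives > 20000 nM, which is a limit of the assay and not a number.
Compound 2, `C=C1C[C@]23C[C@@]1(O)CC[C@H]2c1ccc(O)c(C)c1[C@@H]3Cn1cc(-c2ccc(C(F)(F)F)cc2)nn1`: in this assay compound 2 gives 10400 nM.
Compound 3, `C=C1C[C@]23C[C@@]1(O)CC[C@H]2c1ccc(O)c(C)c1[C@@H]3Cn1cc(-c2ccc(Br)cc2)nn1`: in this assay compound 3 gives > 20000 nM, again a limit of the assay.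

Compound 3 therefore sits at the limit of > 20000 nM in this assay, at which 2 of the 3 values shown sit, and only compound 2 carries an actual number in this set. Compound 4, `C=C1C[C@]23C[C@@]1(O)CC[C@H]2c1ccc(O)c(C)c1[C@@H]3Cn1cc(-c2ccccc2)nn1`, differs from compound 3 by hydrogen in place of bromo on an aromatic carbon.

For the measured compounds named here, no measured step removes a bromo for a hydrogen, so the evidence bearing on this change is indirect. Going by the values given here, the step of an at least 1.9-fold higher number from compound 2 to compound 3 (0.28 log units; that floor lies within the scatter) shows that exchanging one para group for another moved the number back to the limit, while a step that the two limits leave unreadable from compound 1 to compound 3 remains unreadable between two limits, and an at least 1.9-fold lower number from compound 1 to compound 2 (0.28 log units; that floor lies within the scatter) is the only step that reached a numbered value at all. With compound 3 already at the limit, the aryl change to compound 4 is not expected to produce a step beyond the scatter in this assay in either direction, and another limit is the most likely outcome.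

Compound 4 is therefore estimated at 20000 nM, in a range from 7000 nM to 60000 nM, meaning an expected step of a number no higher from compound 3 to compound 4 (the limit leaves the size open).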

Compound 4, half-maximal inhibitory concentration: > 20000 nM
Compound 4: a limit, no number (the forecaster's own chance of this, stated with the estimate: 60%); the middle value sits exactly at the limit.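

With compound 4, the bare phenyl ring also fails to give a number in this assay, so removing the bromo from the aromatic carbon leaves the series where it was, and its result is a limit of the assay, as with compound 3 and compound 1. Hydrogen, bromo and the pyridin-2-yl exchange therefore all end in the same place, a picture now shared by most of the set: the limit of > 20000 nM in this assay, at which 3 of the 4 values shown sit. The steps among these three compounds cannot be read, each joining two limits, and the one step that can be read is an at least 1.9-fold higher number from compound 2 to compound 4 (0.28 log units; that floor lies within the scatter), so on these data the trifluoromethyl group is not set apart from hydrogen beyond the scatter.

The compounds shown leave open whether a group of another kind on this ring, such as an amine, a carboxylic acid or a methoxy group, would bring a clear numbered value in this assay. They also leave open how far compound 1, compound 3 and compound 4 lie from one another past the limit, and so whether any order exists among them.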